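From formyl to propylcarbonyl: working notes on compound 4

The source may hold more compounds than are shown below. What is called first, only, known or untested is meant among the compounds shown, and "the series" means these compounds.

In a functional assay on the whole organism for positive allosteric modulation, with Mus musculus as the target (a higher number here means that more compound is needed for the effect, a lower number that less compound is needed), compound 3 (`CN(C)C1CCCC1N(C=O)c1ccccc1`) gives 40 mg/kg as its reading. Compound 2 (`CCC(=O)N(c1ccc(OC)cc1)C1CCCC1N(C)C`) gives 30 mg/kg; 30 mg/kg (2 entries) in both of its entries, within the scatter of compound 3. Compound 1 (`CCC(=O)N(c1ccc(Cl)cc1)C1CCCC1N(C)C`) gives 3 mg/kg as its reading, lower than compound 3 and beyond the scatter.

Compound 4 (`CCCC(=O)N(c1ccccc1)C1CCCC1N(C)C`) follows from compound 3 by one change: propyl in place of hydrogen on a carbonyl carbon (propyl in place of hydrogen on a carbonyl carbon, or formyl to propylcarbonyl).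

Within the data shown here, no measured pair isolates this change, since compounds 1 and 2 differ from compound 3 in more than one place. Both carry a longer chain on the carbonyl carbon than compound 3, yet only compound 1 at 3 mg/kg sits clearly lower, and compound 2 at 30 mg/kg; 30 mg/kg (2 entries) goes against that trend. A moderate move towards less compound needed is therefore expected, and it may prove no larger than the scatter. The estimate is a 2.7-fold lower number from compound 3 to compound 4 (0.43 log units; beyond the scatter) in that direction. Compound 4 is expected at 15 mg/kg (estimated range 4 mg/kg to 50 mg/kg).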

Compound 4, dose for half-maximal effect: 6 mg/kg
Compound 4: middle estimate off by 2.5-fold (0.40 log units), on the high side, within the range that was stated.
By their numbers in this assay, from the lowest: compounds 1 and 4 (each within the scatter of the next); then compound 3.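

In this assay, among these compounds, propyl in place of hydrogen on a carbonyl carbon gives a 6.7-fold lower number from compound 3 to compound 4 (0.82 log units; beyond the scatter), the first reading of this change on its own. Compounds 1 and 2 differ from compound 3 in more than one place, so they could not separate this change from their other differences. The step shows that, with the rest of the core held constant, this position accepts the propyl chain and that less compound is needed with it in this assay. Nothing shown accounts for the size or direction of this step.

On these data alone, the series shows only one chain at this carbonyl carbon as a single change, so the response to methyl, a longer chain such as pentyl, or a cyclopropyl group remains open. Also open, as far as these compounds go, is whether the step keeps its size on the cores of compound 1 and compound 2.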